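The source may hold more compounds than are shown below. What is called first, only, known or untested is meant among the compounds shown, and "the series" means these compounds.

In a functional assay on microsomes for inhibition, with a stated time of 1 h (a higher number here means a weaker inhibitor, a lower number a stronger inhibitor), compound 1 `CCOC(=O)c1cnn(-c2nc(-c3ccccc3F)c(C#N)c(=O)n2C)c1N` gives 94 ug/mL, compound 2 `CCOC(=O)c1cnn(-c2nc(-c3cccc(OC)c3OC)c(C#N)c(=O)n2C)c1N` gives 57 ug/mL and compound 3 `COc1cccc(-c2nc(NN)n(C)c(=O)c2C#N)c1OC` gives 37 ug/mL. The number for compound 3 lies within the scatter of the number for compound 2, and beyond the scatter below the number for compound 1.

Compound 4 `COc1cccc(-c2nc(SC)n(C)c(=O)c2C#N)c1OC` has not been measured yet. It differs from compound 3 by one change: methylsulfanyl in place of aminoamino on an aromatic carbon. This group sits between two ring nitrogen atoms.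

For the measured compounds named here, the only measured step that changes one place is a 1.6-fold lower number from compound 1 to compound 2 (0.22 log units; within the scatter), and it concerns a different group, so it offers little guidance here. Compound 2 and compound 3 do differ at this same place, yet compound 2 at 57 ug/mL and compound 3 at 37 ug/mL stay within the scatter of each other. No step beyond the scatter is therefore expected in this assay, in either direction.

The estimated change is a 1.3-fold higher number from compound 3 to compound 4 (0.11 log units; within the scatter), which leaves the direction open. For compound 4 the expected value is 48 ug/mL, with an estimated range from 20 ug/mL to 115 ug/mL.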

Compound 4, half-maximal inhibitory concentration: 48 ug/mL
The estimate for compound 4 equals the measured number at the digits printed; the measured number falls inside the stated range.
By their numbers in this assay, from the lowest: compounds 3, 4, 2 and 1 (each within the scatter of the next, the first and the last beyond it).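

Placing methylsulfanyl where compound 3 has aminoamino gives a 1.3-fold higher number from compound 3 to compound 4 (0.11 log units; within the scatter) in this assay, the first reading of a one-place change at this position between two ring nitrogen atoms. Hydrogen-bond donors on this group go from 2 to 0 while the group stays at 2 heavy atoms, and the number does not move beyond the scatter, so in this pair those donors show no measurable link to the read-out. The data offer nothing measured that could account for this result.

As far as these compounds go, whether a simple amine, a carboxylic acid or a longer chain such as butylsulfanyl at this position would produce a step beyond the scatter remains open. Also open, from the compounds shown here alone, is whether methylsulfanyl would give a similar reading with 2-fluorophenyl in place of 2,3-dimethoxyphenyl.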